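The source may report more compounds than this note shows. Statements on the series, on what has been measured and on what is new or still open speak of the compounds shown alone.

Compound 1 `CCOC(=O)CN(C)CC#Cc1cc2ncnc(Nc3ccc(OCc4cccc(F)c4)c(Cl)c3)c2s1`: 26 uM
Compound 2 `CCCN(CC#Cc1cc2ncnc(Nc3ccc(OCc4cccc(F)c4)c(Cl)c3)c2s1)CCC`: 26.5 uM
Compound 3 `COCC#Cc1cc2ncnc(Nc3ccc(OCc4cccc(F)c4)c(Cl)c3)c2s1`: > 33 uM (a limit of the assay)

In an ADME assay on HepG2 cells (Homo sapiens) for cytotoxicity (on this read-out lower numbers stand for higher toxicity in this test and higher numbers for lower toxicity in this test), compound 2 gives 26.5 uM and stands level with compound 1, as a 1.0-fold higher number from compound 1 to compound 2 (0.01 log units; within the scatter) shows. Compound 3 reports only a limit, > 33 uM, so its true number is not known.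

The next compound, compound 4 `Fc1cccc(COc2ccc(Nc3ncnc4cc(C#CCN5CCCC5)sc34)cc2Cl)c1`, differs from compound 2 at a single place: pyrrolidin-1-yl in place of dipropylamino on a saturated chain carbon bound to a triple-bonded carbon. Two measured steps change the group at this same place. The first is the step already given, a 1.0-fold higher number from compound 1 to compound 2 (0.01 log units; within the scatter), which replaces one amino group with another. The second is an at least 1.2-fold higher number from compound 2 to compound 3 (0.09 log units; that floor lies within the scatter), which replaces dipropylamino with methoxy and rests on a limit. Neither shows a change beyond the scatter in this assay, so no shift in either direction is expected from the new ring. The expected change is a 1.0-fold higher number from compound 2 to compound 4 (0.01 log units; within the scatter), which is no step beyond the scatter. For compound 4 the estimated value is 27 uM, with an expected range from 15 uM to 40 uM.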

Compound 4, half-maximal toxic concentration: 4.9 uM
Compound 4: the middle estimate sits 5.5-fold (0.74 log units) above what was measured; the measured number lies below the stated range.
By their numbers in this assay, from the lowest: compound 4; then compounds 1 and 2 (each within the scatter of the next). At a limit, above all of these: compound 3.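

In this assay, for the compounds shown here, the earlier compounds suggested a position that tolerates change, but pyrrolidin-1-yl breaks that picture, with a 5.4-fold lower number from compound 2 to compound 4 (0.73 log units; beyond the scatter). The shift does not depend on which open-chain amino group serves as the reference, since the other one gives a 5.3-fold lower number from compound 1 to compound 4 (0.72 log units; beyond the scatter), and the comparison with methoxy gives an at least 6.7-fold lower number from compound 3 to compound 4 (0.82 log units; beyond the scatter). Compound 3 stands at a limit, so that last step is only a floor: the limit of > 33 uM in this assay, at which 1 of the 4 values shown sits.

With a single ring among these groups, it remains open whether the higher toxicity in this test goes with the ring itself or with the smaller group, and a piperidine ring, a morpholine ring or an open-chain diethylamino group would help separate the two. From the compounds shown here alone, the true number of compound 3, and so the full size of its step, also remains open.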